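The compounds below may be only part of what the source reports. "The series", "measured", "known", "first", "only" and "open" are said of these compounds alone.

Working notes on a small solubility set. Compound 2 `CC(=O)NC[C@H]1CN(c2ccc(OC[C@H](O)CNc3ccccc3)c(F)c2)C(=O)O1` gives 296000 nM in a physicochemical assay for solubility, read by HPLC; a higher number here means a more soluble compound, a lower number a less soluble compound. Compound 1 `COc1ccc(NC[C@@H](O)COc2ccc(N3C[C@H](CNC(C)=O)OC3=O)cc2F)cc1` gives 1300 nM in this assay. The change between them, (methoxy in place of hydrogen on an aromatic carbon), made the step of a 230-fold lower number from compound 2 to compound 1 (2.36 log units; beyond the scatter). Compound 3 `CC(=O)NC[C@H]1CN(c2ccc(OC[C@@H]3CN(c4ccccc4)C(=O)O3)c(F)c2)C(=O)O1` is built on a different core; the difference between the two cores of compound 2 and compound 3 is not broken down here, and compound 3 gives 14000 nM in this assay, the second highest of the three numbers, its distances to compound 1 and to compound 2 both beyond the scatter. Among the measured compounds shown here, compound 4 `COc1ccc(N2C[C@@H](COc3ccc(N4C[C@H](CNC(C)=O)OC4=O)cc3F)OC2=O)cc1`, not yet measured, differs from compound 3 by methoxy in place of hydrogen on an aromatic carbon, the same change as the one from compound 2 to compound 1, at a place described in the same words. For the measured compounds named here, because the earlier step of a 230-fold lower number from compound 2 to compound 1 (2.36 log units; beyond the scatter) was large, a lower number is expected for compound 4 as well, though a smaller step is assumed since the core is not the same and only one prior example exists. The expected step is a 14-fold lower number from compound 3 to compound 4 (1.15 log units; beyond the scatter). Compound 4 is estimated at 1000 nM, with a plausible range from 200 nM to 5000 nM in this assay.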

Compound 4, solubility: 132000 nM
The estimate for compound 4 lay 130-fold (2.12 log units) below the measured number; the measured number lies above the stated range.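

In this assay, the change from phenyl to 4-methoxyphenyl gives a 9.4-fold higher number from compound 3 to compound 4 (0.97 log units; beyond the scatter) on the core of compound 3, while methoxy in place of hydrogen on the core of compound 2 gives a 230-fold lower number from compound 2 to compound 1 (2.36 log units; beyond the scatter) in the opposite direction. Across these two pairs, then, neither the direction nor the size of the step carries from one core to the other, and a step read on one of these cores is a poor guide to the other. Two pairs show only that transfer failed once, not how the change behaves on other cores in the series, and nothing available bears on why the two steps part.

Open, as far as these compounds go, is whether an amine, a carboxylic acid or a longer chain such as ethoxy, in place of methoxy at the same place on the aromatic ring, would also give steps that differ in direction between the two cores. Also open, from the compounds shown here alone, is whether a third core would follow the step to compound 1 or the step to compound 4.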